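Swapping the Aryl Amide Head on a Weak Inhibitor

The source may hold more compounds than are shown below. What is called first, only, known or untested is meant among the compounds shown, and "the series" means these compounds.

Compound 1, `Cc1cnc(C(=O)Nc2cc(OCCC3CCN(C(=O)OC(C)(C)C)CC3)cc3cccnc23)cn1`: 9330 nM
Compound 2, `Cc1cnc(C(=O)Nc2cc(OCCC3CCNCC3)cc3cccnc23)cn1`: 8330 nM

Among the compounds with values here, in a functional assay on BXPC-3 cells (Homo sapiens) for inhibition, read by MTT assay, with a stated time of 72 h (on this read-out lower numbers stand for stronger inhibition and higher numbers for weaker inhibition), compound 1 stands alongside compound 2, the only other measured compound, and the step of a 1.1-fold lower number from compound 1 to compound 2 (0.05 log units; within the scatter) lies within the scatter. Compound 3, `CC(C)(C)OC(=O)N1CCC(CCOc2cc(NC(=O)c3ncccn3)c3ncccc3c2)CC1`, carries the change (pyrimidin-2-yl in place of 5-methylpyrazin-2-yl on a carbonyl carbon). Within the data shown here, no measured pair tests this exchange; the single recorded step concerns a different part of the molecule, so nothing here points in either direction. The expected step is therefore a 1.1-fold higher number from compound 1 to compound 3 (0.03 log units; within the scatter), a move not beyond the scatter, with wide uncertainty. Compound 3 is estimated at 10000 nM, ranging from 3000 nM to 30000 nM.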

Compound 3, half-maximal inhibitory concentration: > 10000 nM
Compound 3: only a limit was reported (the forecaster's own chance of this, stated with the estimate: 15%); the middle value sits exactly at the limit.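

Within the data shown here, this is the first look at the group on the carbonyl carbon: compound 3 gives > 10000 nM in this assay and that is a limit, not a number. The step of an at least 1.0-fold higher number from compound 1 to compound 3 (0.03 log units; that floor lies within the scatter) shows no sign that pyrimidin-2-yl in place of 5-methylpyrazin-2-yl brings stronger inhibition. Its true size cannot be read because the result stops at a limit: the limit of > 10000 nM in this assay, at which 1 of the 3 values shown sits.

On these data alone, whether any group at this place can strengthen inhibition remains open. So does what an amine or a carboxylic acid on that ring would do.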